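A few compounds are considered here, and "the series" means these few. Any claim that something is new, unique, unknown or untested is made for them only; others in the source may bear on it.

Measured so far in an assay on microsomes from liver for inhibition of sterol O-acyltransferase 1 (Rattus norvegicus); a lower number here means a stronger inhibitor, a higher number a weaker inhibitor:

Compound 1 `CCCCCC(=O)Nc1cc(-c2ccccc2)c(-c2ccccc2)nn1`; in this assay compound 1 gives only a limit, > 300000 nM.
Compound 2 `CCCCCCCOc1cc(-c2ccccc2)c(-c2ccccc2)nn1`; in this assay compound 2 gives 58000 nM.
Compound 3 `CCCCCCCCCOc1cc(-c2ccccc2)c(-c2ccccc2)nn1`; in this assay compound 3 gives 180000 nM.

Compound 2 holds the lowest of the two numbers shown; its nearest neighbour is compound 3, and the step of a 3.1-fold higher number from compound 2 to compound 3 (0.49 log units; beyond the scatter) lies beyond the scatter. Compound 1 is known only as a limit.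

The next compound is compound 4 `CCCCCCS(=O)(=O)c1cc(-c2ccccc2)c(-c2ccccc2)nn1`. It differs from compound 2 in one place: hexylsulfonyl in place of heptyloxy on an aromatic carbon.

Within the data shown here, no measured step changes the heptyloxy group into a sulfonyl group, so none bears directly on this change. The two neighbouring steps give the scale of what the series has shown: an at least 5.1-fold lower number from compound 1 to compound 2 (0.71 log units; beyond the scatter), where an amide-bearing compound sat at the limit, and a 3.1-fold higher number from compound 2 to compound 3 (0.49 log units; beyond the scatter), where a longer chain cost potency. Both are modest. On that basis a modest step is expected for compound 4 in this assay, toward weaker inhibition, with a real chance that the result again reaches (the limit of > 300000 nM in this assay, at which 1 of the 3 values shown sits).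

Compound 4 is estimated at 150000 nM, within a range of 40000 nM to 600000 nM, which means an expected step of a 2.6-fold higher number from compound 2 to compound 4 (0.41 log units; beyond the scatter).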

Compound 4, half-maximal inhibitory concentration: 60000 nM
The estimate for compound 4 lay 2.5-fold (0.40 log units) above the measured number; the range from low to high includes it.
By their numbers in this assay, from the lowest: compounds 2 and 4 (each within the scatter of the next); then compound 3. At a limit, above all of these: compound 1.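

In this assay, the aromatic carbon next to the ring nitrogen carries hexylsulfonyl in place of heptyloxy with a step of a 1.0-fold higher number from compound 2 to compound 4 (0.01 log units; within the scatter), so an ether link is not required to hold the level of compound 2 at this position. The second comparison is an at least 5.0-fold lower number from compound 1 to compound 4 (0.69 log units; beyond the scatter), which places both the ether and the sulfonyl compound clear of the amide compound. Among these compounds, compound 1 is the only compound known just as a limit: the limit of > 300000 nM in this assay, at which 1 of the 4 values shown sits.

The change swaps the link and shortens the chain at once, so the contribution of each remains unseparated, and a heptylsulfonyl or hexyloxy group would be needed to pull them apart. From the compounds shown here alone, whether a thioether or an amine link at this position behaves like the sulfonyl group or like the amide also stays open.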